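This account rests on a few compounds, and the source may have more. Where it says the series, first, only, none or still open, it means among the compounds named here.

Cytotoxicity across the series is read in a toxicity assay on NIH3T3 cells (Mus musculus) for cytotoxicity, read by resazurin assay; a higher number here means that more compound is needed for the effect, a lower number that less compound is needed. Compound 1 `c1ccc(-c2ccc(Cn3cncc3CNc3cccc(-c4ccccc4)c3)cc2)cc1` gives 10000 nM in this assay. Compound 2 `COC(=O)c1ccc(NCc2cncn2Cc2ccccc2C)cc1-c1ccccc1` gives 10000 nM in this assay, level with compound 1 at the digits shown and within the scatter of it. Compound 3 `c1ccc(-c2ccc(Cn3cncc3CNc3ccc(-c4nc5ccccc5o4)c(-c4ccccc4)c3)cc2)cc1` is reported in this assay only as a limit, > 10000 nM. For the measured compounds named here, the one measured step between compounds differing in a single place is a number no lower from compound 1 to compound 3 (the limit leaves the size open), and it rests on (the limit of > 10000 nM in this assay, at which 1 of the 3 values shown sits), so its size stays open.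

Compound 4 `COC(=O)c1ccc(NCc2cncn2Cc2cccc(C(C)(C)C)c2)cc1-c1ccccc1` is the next member to be measured in this assay. It differs from compound 2 by 3-(tert-butyl)phenyl in place of 2-methylphenyl on a saturated chain carbon bound to an aromatic nitrogen. Going by the values given here, no measured step touches this change: the only step in hand concerns another group at another place and ends at a limit. Compound 1 and compound 2 sit at the same reading, and compound 3 stays at the limit, so nothing in the set points toward a move beyond the scatter. For compound 4 the expected step is therefore no change at the digits printed from compound 2 to compound 4 (within the scatter). Compound 4 is accordingly estimated at 10000 nM, within a range of 5000 nM to 20000 nM.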

Compound 4, half-maximal effective concentration: > 1000 nM
Compound 4: only a limit was reported (the forecaster's own chance of this, stated with the estimate: 45%); the middle value does not contradict the limit.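

Compound 4 stands in this assay only as a limit, > 1000 nM, so no step can be read from compound 2 to compound 4: the limit of > 1000 nM in this assay, at which 1 of the 4 values shown sits.

The compounds shown leave open whether 3-(tert-butyl)phenyl in place of 2-methylphenyl moves the reading at all.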